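The compounds below may be only part of what the source reports. "The series", "measured", "known", "first", "only" and "open" are said of these compounds alone.

Measured compounds:
compound 1 `COc1ccc(/C=C/C[C@H]2C[C@@H]([C@@H](O)c3ccc(OC)c(OC)c3)CO[C@@H]2c2ccccc2)cc1OC` with 17000 nM in a functional assay on HeLa cells (Homo sapiens) for cytotoxicity, read by WST assay, with a stated time of 48 h; a lower number here means a stronger inhibitor, a higher number a weaker inhibitor
compound 2 `Oc1ccccc1/C=C/C[C@H]1C[C@@H]([C@@H](O)c2ccccc2)CO[C@@H]1c1ccccc1` with 21800 nM
compound 3 `COc1cccc(/C=C/C[C@@H]2C[C@@H]([C@@H](O)c3ccc(OC)c(OC)c3)CO[C@H]2c2ccc(OC)c(OC)c2)c1` with 16400 nM

All three compounds share a core and were read in this assay. Among the measured compounds shown here, compound 2 sits with the highest of the three numbers, yet its gap to compound 1 and its gap to compound 3 both lie within the scatter, so the three values cannot be told apart and no compound among them can be called the weaker or the stronger one.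

The step from compound 2 leads to compound 4 `O[C@@H](c1ccccc1)[C@H]1CO[C@H](c2ccccc2)[C@@H](C/C=C/C2CCCCC2)C1`. The change is counted as follows: cyclohexyl in place of 2-hydroxyphenyl on a double-bonded chain carbon bound to a double-bonded chain carbon. For the measured compounds named here, no measured pair shows this kind of change, so there is no step to lean on. The three values seen so far stay close together despite differing groups, and the account therefore expects no step beyond the scatter from compound 2 to compound 4 in this assay, with the step of a 1.1-fold higher number from compound 2 to compound 4 (0.06 log units; within the scatter) as the central guess. Compound 4 is estimated at 25000 nM, within a range from 10000 nM to 60000 nM.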

Compound 4, half-maximal inhibitory concentration: 6440 nM
For compound 4 the middle estimate is 3.9-fold (0.59 log units) above the measured one; the measured number lies below the stated range.
By their numbers in this assay, from the lowest: compound 4; then compounds 3, 1 and 2 (each within the scatter of the next).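

In this assay, among the compounds shown here, the end of the chain proves to be a place where the number can move: cyclohexyl in place of 2-hydroxyphenyl on a double-bonded chain carbon bound to a double-bonded chain carbon gives a 3.4-fold lower number from compound 2 to compound 4 (0.53 log units; beyond the scatter) and so forms the first measured pair in this set, with a step beyond the scatter. The 2-hydroxyphenyl group is thus not required at this place for activity in this assay, and a non-aromatic ring with no hydrogen-bond donor or acceptor gives the lower number, although this modest step rests on a single pair. Nothing measured here bears on why the number falls.

The compounds shown do not separate the loss of the hydroxyl from the loss of the aromatic ring, which an unsubstituted phenyl at this place could do. They also leave open how an open-chain tert-butyl group or a piperidinyl ring bearing its amine would read here.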